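Replacing azido with a phenyl triazole: does stability hold?

A few compounds are considered here, and "the series" means these few. Any claim that something is new, unique, unknown or untested is made for them only; others in the source may bear on it.

Compound 1 `COc1ccc(-c2c(C)nc3c(N4CC[C@@H](NS(=O)(=O)c5ccc(C)cc5)C4)cc(C)nn23)cc1OC`: > 95%
Compound 2 `COc1ccc(-c2c(C)nc3c(N4CC[C@@H](N=[N+]=[N-])C4)cc(C)nn23)cc1OC`: > 95%

These two entries come from an ADME assay on microsomes from liver (Mus musculus) for metabolic stability, read by LC-MS, with NADPH named in the record, with a stated time of 60 min, tested at 1 uM, in the absence of a further agent; a higher number here means that more of the compound is left, a lower number that less of the compound is left. Compound 2 gives > 95%, which is a limit and not a number. Compound 1 gives > 95%, which is also a limit. Both compounds therefore stand together at the top of the scale: the limit of > 95% in this assay, at which 2 of the 2 values shown sit.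

Compound 3 `COc1ccc(-c2c(C)nc3c(N4CC[C@@H](n5cc(-c6ccccc6)nn5)C4)cc(C)nn23)cc1OC` keeps the shared core and changes one group: 4-phenyl-1H-1,2,3-triazol-1-yl in place of azido on a saturated ring carbon. In words, 4-phenyl-1H-1,2,3-triazol-1-yl takes the place of azido on a saturated ring carbon.

Going by the values given here, only one measured step bears on this change, and its size cannot be read: a step that the two limits leave unreadable from compound 1 to compound 2. It concerns the same saturated ring carbon, and neither compound comes off the limit there. A step no larger than the usual scatter is therefore expected in this assay, although a real fall remains possible and would be the only readable direction. The expected step is a number at least 5 percentage points lower from compound 2 to compound 3 (that floor lies within the scatter). For compound 3 the estimate is 90%, with an expected range from 65% to 100%.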

Compound 3, percent of the compound remaining: "unstable" (no number reported)
For compound 3 the study gives words and no number; the estimate stays without a comparison.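

In this assay compound 3 is reported as "unstable" (no number reported), without a number, so no new step can be read from compound 2 to compound 3. Compound 2 gives > 95%, which is a limit. The compounds shown leave open how much of compound 3 remains, and which part of the 4-phenyl-1H-1,2,3-triazol-1-yl group goes with this result.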